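This account rests on a few compounds, and the source may have more. Where it says the series, first, only, none or still open, it means among the compounds named here.

The study covers three measured compounds and one still untested. Compound 3, `N#Cc1ccc(-c2cs/c(=N/NC(=O)CSc3nnnn3-c3ccccc3)n2-c2ccccc2)cc1`, was tested in a functional assay on C6 cells (Rattus norvegicus) for cytotoxicity, read by MTT assay, with a stated time of 24 h, tested at 100 ug/mL (a lower number here means a stronger effect, a higher number a weaker effect of the compound at the concentration tested), and gives 59.8%. Compound 1, `Cn1nnnc1SCC(=O)N/N=c1/scc(-c2ccc(C#N)cc2)n1-c1ccccc1`, differs from compound 3 by methyl in place of phenyl on an aromatic nitrogen, and in this assay compound 1 gives 30.9%, which amounts to a number 28.9 percentage points lower from compound 3 to compound 1 (beyond the scatter). Compound 2, `O=C(CSc1nnnn1-c1ccccc1)N/N=c1/scc(-c2ccccc2)n1-c1ccccc1`, carries a different core: the two cores differ by hydrogen in place of cyano on an aromatic carbon. In this assay compound 2 gives 35.8%, and the step is a number 24 percentage points higher from compound 2 to compound 3 (beyond the scatter). Compound 2 and compound 1 lie within the usual scatter of each other, so nothing separates them, while compound 3 stands beyond the scatter above both.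

Compound 4, `Cn1nnnc1SCC(=O)N/N=c1/scc(-c2ccccc2)n1-c1ccccc1`, has not been measured. It differs from compound 2 by methyl in place of phenyl on an aromatic nitrogen. Among the compounds with values here, the surroundings of the changed position read the same for both pairs, so this is the same change as the one from compound 3 to compound 1, carried out on the core of compound 2 instead. That earlier change produced a number 28.9 percentage points lower from compound 3 to compound 1 (beyond the scatter). Within the data shown here, for compound 4 a smaller step is expected, a number 20.8 percentage points lower from compound 2 to compound 4 (beyond the scatter), since compound 2 already starts from 35.8% and a lowering of the earlier size would push the read-out close to the lowest numbers this kind of measurement reports; moreover only one example of the change exists, taken from a different starting point. The estimate for compound 4 in this assay is therefore 15%, expected to fall between 5% and 30%.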

Compound 4, a percentage reported as activity, at one concentration (the size of the read-out at that concentration, not a potency): 38.8%
Beside the measured number, compound 4's estimate is 23.8 percentage points below it, outside the stated range (above it).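

On the core of compound 2, the change from 1-phenyl-1H-tetrazol-5-yl to 1-methyl-1H-tetrazol-5-yl gives a number 3 percentage points higher from compound 2 to compound 4 (within the scatter) in this assay, whereas on the nitrile-bearing core the same change gave a number 28.9 percentage points lower from compound 3 to compound 1 (beyond the scatter), so the step did not carry over from one core to the other: the same change on two cores in this assay, a number 28.9 percentage points lower (beyond the scatter) from compound 3 to compound 1 and a number 3 percentage points higher (within the scatter) from compound 2 to compound 4, 31.9 percentage points apart, beyond the scatter of two such steps The nitrile group tells the same story from the other side, since its removal with the 1-methyl-1H-tetrazol-5-yl group in place gives a number 7.9 percentage points higher from compound 1 to compound 4 (within the scatter), while its addition with the 1-phenyl-1H-tetrazol-5-yl group in place gave a number 24 percentage points higher from compound 2 to compound 3 (beyond the scatter): the same change on two cores in this assay, a number 24 percentage points higher (beyond the scatter) from compound 2 to compound 3 and a number 7.9 percentage points lower (within the scatter) from compound 4 to compound 1, 31.9 percentage points apart, beyond the scatter of two such steps This shows that in these four compounds the effect of each change depends on the other position, but it does not show why, and a single pair of cores cannot tell which step, if either, would hold on a further core.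

The compounds shown leave open whether the same dependence would appear with an ethyl group or a longer chain on the aromatic nitrogen. They also leave open what an amine or a carboxylic acid in place of the nitrile would do on either side of this comparison.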